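A few compounds are considered here, and "the series" means these few. Any claim that something is new, unique, unknown or untested is made for them only; others in the source may bear on it.

Measured compounds in a functional assay on THP-1 cells (Homo sapiens) for cytotoxicity, read by MTT assay, with a stated time of 24 h; on this read-out higher numbers stand for weaker inhibition and lower numbers for stronger inhibition:
- compound 1 `CCCCCCCCCCn1cc(Cn2nc(N)c3c(C(F)(F)F)cc(-c4ccccc4)nc32)nn1`: 48.7 ug/mL
- compound 2 `Nc1nn(Cc2cn(CC(=O)Nc3ccccc3)nn2)c2nc(-c3ccccc3)cc(C(F)(F)F)c12`: 54.6 ug/mL
- compound 3 `Nc1nn(Cc2cn(CC(=O)Nc3cccc(Cl)c3)nn2)c2nc(-c3ccccc3)cc(C(F)(F)F)c12`: 37 ug/mL

The three numbers fall in a narrow band. Compound 3 cannot be told apart from the others: a 1.3-fold lower number from compound 1 to compound 3 (0.12 log units; within the scatter) and a 1.5-fold lower number from compound 2 to compound 3 (0.17 log units; within the scatter) are both within the scatter, and the swap of the whole side group, a 1.1-fold higher number from compound 1 to compound 2 (0.05 log units; within the scatter), also moves nothing beyond it.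

Compound 4 `Nc1nn(Cc2cn(CC(=O)Nc3ccccc3Br)nn2)c2nc(-c3ccccc3)cc(C(F)(F)F)c12` differs from compound 3 by 2-bromophenyl in place of 3-chlorophenyl on an amide-type nitrogen. The step that bears on it most directly is a 1.5-fold lower number from compound 2 to compound 3 (0.17 log units; within the scatter), where a halogen was put onto this phenyl ring; that step stayed within the scatter. From the compounds shown here alone, nothing measured here speaks to bromine or to a halogen at the 2-position, so that part of the change is untested. Among the measured compounds shown here, with every step in this assay so far within the scatter, the expectation for compound 4 in this assay is no change beyond the scatter, a 1.2-fold higher number from compound 3 to compound 4 (0.08 log units; within the scatter).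

Compound 4 is therefore expected to give about 44 ug/mL in this assay, with a range of 25 ug/mL to 80 ug/mL.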

Compound 4, half-maximal inhibitory concentration: 95.3 ug/mL
For compound 4 the middle estimate is 2.2-fold (0.34 log units) below the measured one; measured number above the stated range.
By their numbers in this assay, from the lowest: compounds 3, 1, 2 and 4 (each within the scatter of the next, the first and the last beyond it).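

In this assay, among the compounds shown here, the change on the amide-type nitrogen gives the first step beyond the scatter (a 2.6-fold higher number from compound 3 to compound 4 (0.41 log units; beyond the scatter)), so the number can respond to what the phenyl ring carries, though the step is modest. The other two steps to compound 4 stay within the scatter, both for putting a bromine onto the phenyl ring (a 1.7-fold higher number from compound 2 to compound 4 (0.24 log units; within the scatter)) and for the swap of the whole side group from nonyl (a 2.0-fold higher number from compound 1 to compound 4 (0.29 log units; within the scatter)), so the separation rests on the pair compound 3 and compound 4 alone. No measurement at hand accounts for this difference.

Halogen identity and ring position change together between compound 3 and compound 4, so the compounds shown do not separate the two. Also open, from the compounds shown here alone, is how this assay reads for an amine or a carboxylic acid on the phenyl ring.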